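This account rests on a few compounds, and the source may have more. Where it says the series, first, only, none or still open, it means among the compounds named here.

In an ADME assay on SH-SY5Y cells (Homo sapiens) for cytotoxicity, read by MTT assay, with a stated time of 24 h, tested at 100 uM (on this read-out lower numbers stand for a stronger effect and higher numbers for a weaker effect at the one concentration tested), compound 1 `COc1cc2c(cc1O)CCC(C)(CC(=O)O)O2` gives 53.1%. Compound 2 `COc1cc2c(cc1O)CCC(C)(CCNC(=O)C[C@H]1OC(O)[C@H](O)[C@@H](O)[C@@H]1O)O2` gives 56.6% in this assay, and of the two numbers shown it is the larger one, though its gap to compound 1 lies within the scatter. Compound 3 `COc1cc2c(cc1O)CCC(C)(CCNC(C)=O)O2` is the next compound; (hydrogen in place of 3,4,5,6-tetrahydroxyoxan-2-yl on a saturated chain carbon bound to a carbonyl carbon). Within the data shown here, no step between measured compounds is available to guide the reading, so the account rests on the two values alone. The expected step is a number 1.6 percentage points lower from compound 2 to compound 3 (within the scatter), that is, nothing beyond the scatter. The estimate for compound 3 in this assay is 55%, within a range from 40% to 70%.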

Compound 3, a percentage reported as activity, at one concentration (the size of the read-out at that concentration, not a potency): 57.9%
Estimate against measurement, compound 3: 2.9 percentage points below, and the stated range covers the measured number.
By their numbers in this assay, from the lowest: compounds 1, 2 and 3 (each within the scatter of the next).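

Hydrogen in place of 3,4,5,6-tetrahydroxyoxan-2-yl on a saturated chain carbon bound to a carbonyl carbon gives a number 1.3 percentage points higher from compound 2 to compound 3 (within the scatter) in this assay, so this read-out does not separate compounds with and without that group. Acetamidomethyl in place of carboxy on a saturated chain carbon bound to a saturated ring carbon gives a number 4.8 percentage points higher from compound 1 to compound 3 (within the scatter), which likewise does not separate the two. Nothing available explains these small steps. As far as these compounds go, whether a phenyl group or a longer alkyl chain at the first of these positions would leave the number within the scatter remains open. So does whether an amine at the second would.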